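The source may hold more compounds than are shown below. What is called first, only, known or untested is meant among the compounds shown, and "the series" means these compounds.

In a functional assay on HT-29 cells (Homo sapiens) for inhibition, read by sulforhodamine B assay, with a stated time of 48 h (on this read-out lower numbers stand for stronger inhibition of growth and higher numbers for weaker inhibition of growth), compound 1 `c1cc(C2CCCCC2)ccc1NC1=NCCO1` gives 12800 nM and compound 2 `c1cc(NC2=NCCO2)cc(OC2CCCC2)c1` gives 52200 nM. Compound 2 therefore holds the higher of the two numbers, meaning weaker inhibition of growth than compound 1, by a gap beyond the scatter. Compound 3 `c1ccc(Oc2cccc(NC3=NCCO3)c2)cc1` is not yet measured. Its change from compound 2 is phenyl in place of cyclopentyl on an oxygen on an aromatic ring. Among the compounds with values here, no measured pair shows this change. No step beyond the scatter is expected in this assay, and the expected change is a 1.5-fold lower number from compound 2 to compound 3 (0.17 log units; within the scatter). For compound 3 the estimate is 35000 nM, with an expected range of 12000 nM to 90000 nM.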

Compound 3, concentration for 50% growth inhibition: 5500 nM
Compound 3: the middle estimate sits 6.4-fold (0.80 log units) above what was measured; measured number outside the range, below it.
By their numbers in this assay, from the lowest: compound 3; then compound 1; then compound 2.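

In this assay the change of cyclopentyl to phenyl on an oxygen on an aromatic ring gives a 9.5-fold lower number from compound 2 to compound 3 (0.98 log units; beyond the scatter) and is beyond the scatter. The group on this oxygen therefore matters: here the six-membered aromatic ring gives stronger inhibition of growth than the five-membered non-aromatic ring. Nothing available explains this step. Still open, on these data alone, is whether the gain survives a carboxylic acid or an amine on the phenyl. Also open, as far as these compounds go, is how a benzyl group on the same oxygen would compare.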